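From methoxy to bromo in an antiproliferative series

The source may report more compounds than this note shows. Statements on the series, on what has been measured and on what is new or still open speak of the compounds shown alone.

In a functional assay on DU-145 cells (Homo sapiens) for antiproliferative activity, read by MTT assay, with a stated time of 72 h (a higher number here means a weaker inhibitor, a lower number a stronger inhibitor), the compounds measured so far gave these values:
- Compound 1 `COc1ccccc1/C=C/C(=O)c1ccc(OCC(=O)N[C@H]2CCOC2=O)cc1` gives 10100 nM
- Compound 2 `CCCCCCCCCCSC(=S)N[C@H]1CCOC1=O` gives > 64000 nM (a limit, not a number)
- Compound 3 `CCOc1ccccc1OCCSC(=S)N[C@H]1CCOC1=O` gives 28300 nM

Only two of these results are true numbers, and compound 1 holds the lower one. Compound 3 is its nearest neighbour, and its higher number lies beyond the usual scatter of repeated measurements. The result for compound 2 is only a limit.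

The next compound to be tested is compound 4 `O=C(COc1ccc(C(=O)/C=C/c2ccccc2Br)cc1)N[C@H]1CCOC1=O` and it keeps the core of compound 1 apart from one group. The change is bromo in place of methoxy on an aromatic carbon in which the 2-methoxyphenyl becomes 2-bromophenyl: bromo in place of methoxy on an aromatic carbon, ortho to a large group.

Among the compounds with values here, no two measured compounds differ by this swap, so the data offer no direct guide to its size or direction. Within the data shown here, the best starting point is compound 1 at 10100 nM and, with only one small group replaced, no step beyond the scatter is expected in this assay here. The estimated step of a 1.1-fold lower number from compound 1 to compound 4 (0.05 log units; within the scatter) is therefore small. For compound 4 the estimate is 9000 nM as the expected value, with 3500 nM to 23000 nM as its expected range.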

Compound 4, half-maximal inhibitory concentration: 3540 nM
Compound 4: middle estimate off by 2.5-fold (0.41 log units), on the high side; the range from low to high includes it.
By their numbers in this assay, from the lowest: compound 4; then compound 1; then compound 3. At a limit, above all of these: compound 2.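

In this assay, putting bromo in place of methoxy on an aromatic carbon, ortho to a large group, gives a 2.9-fold lower number from compound 1 to compound 4 (0.46 log units; beyond the scatter). Within the data shown here, this is the first pair of measured compounds that differ in one place, and it shows that the group at this position can change the result by more than the usual scatter, so the position is not a silent one in this assay. Methoxy brings 2 heavy atoms and 1 hydrogen-bond acceptor while bromo brings 1 heavy atom and no acceptor, yet nothing measured here accounts for the gain, so the step records what happened without saying why.

A single pair cannot show whether the gain belongs to bromo alone, and chloro, fluoro, methyl or an amine at the same position could each give a different answer. As far as these compounds go, it also remains open whether the same swap would give a similar step on another carbon of that ring, or whether any change at this position could carry the number much lower than compound 4 reaches.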